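The source may report more compounds than this note shows. Statements on the series, on what has been measured and on what is new or still open speak of the compounds shown alone.

Compound 2 `CCN(CC)c1ccc(NC(=O)c2c(-c3c(Cl)cccc3Cl)noc2CCC2CCCCO2)cc1` holds the lowest number of the two measured in an in vitro assay on CHO-K cells with growth hormone secretagogue receptor type 1 (Homo sapiens) as the target; a higher number here means a weaker inhibitor, a lower number a stronger inhibitor; compound 2 gives 39 nM. Within the data shown here, its nearest neighbour, compound 1 `CCN(CC)c1ccc(NC(=O)c2c(-c3c(Cl)cccc3Cl)noc2CCOC)cc1`, gives 110 nM in this assay, and the only measured step runs a 2.8-fold lower number from compound 1 to compound 2 (0.45 log units; beyond the scatter). Compound 3 `CCN(CC)c1ccc(NC(=O)c2c(-c3c(Cl)cccc3Cl)noc2CCC2OCCO2)cc1` differs from compound 2 in one place: 1,3-dioxolan-2-yl in place of oxan-2-yl on a saturated chain carbon, two bonds along the chain from an aromatic carbon. Among the measured compounds shown here, no measured pair shows this exchange directly; the one step that bears on it, from compound 1 to compound 2, replaced a small open-chain group at the same place with a six-membered oxygen ring and moved the number down by a modest amount. Compound 3 keeps a ring at that spot but a smaller one with a second oxygen, so for compound 3 a step of about a 1.5-fold higher number from compound 2 to compound 3 (0.19 log units; within the scatter) is expected, likely no farther than the scatter. Compound 3 is therefore estimated at 60 nM, in the range 25 nM to 150 nM.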

Compound 3, half-maximal inhibitory concentration: 25 nM
The estimate for compound 3 lay 2.4-fold (0.38 log units) above the measured number; low and high end bracket the measured number.
By their numbers in this assay, from the lowest: compounds 3 and 2 (each within the scatter of the next); then compound 1.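

In this assay, the exchange of oxan-2-yl for 1,3-dioxolan-2-yl on a saturated chain carbon, two bonds along the chain from an aromatic carbon, comes to a 1.6-fold lower number from compound 2 to compound 3 (0.19 log units; within the scatter) and so does not separate the two rings. The six-membered ring with 1 hetero atom and the five-membered ring with 2 hetero atoms read alike at this place. Set against methoxy, 1,3-dioxolan-2-yl gives a 4.4-fold lower number from compound 1 to compound 3 (0.64 log units; beyond the scatter) and so a second ring now stands clear of compound 1, which shows that the earlier gain was not confined to oxan-2-yl.

The compounds shown leave open whether ring oxygen matters at all, as no cyclohexyl group stands at this place, and how a morpholine amine or a carboxylic acid would read there. Nothing at hand says why the two rings read alike or why either stands apart from methoxy.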